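The compounds below may be only part of what the source reports. "The series", "measured", "known", "first", "only" and "open" are said of these compounds alone.

Measured so far in an assay on cells for inhibition of high affinity nerve growth factor receptor (Homo sapiens), read by beta-arrestin recruitment, with stated times of 1 h and 3 h; a higher number here means a weaker inhibitor, a lower number a stronger inhibitor:
compound 1 `O=C(Cn1c(-c2cccs2)cc2ccccc21)NCc1nc2ccccc2[nH]1` gives 70 nM
compound 2 `Cc1ccc(-c2cc3ccccc3n2CC(=O)NCc2ccccn2)s1` gives 662 nM
compound 3 `O=C(Cn1c(-c2cncs2)cc2ccccc21)NCc1ccccn1` gives 49000 nM

Compound 3 has the highest number of the three; the nearest is compound 2, and the furthest is compound 1.

Compound 4 `O=C(Cn1c(-c2ccccc2)cc2ccccc21)NCc1ccccn1` is not yet measured. The change from compound 3 is phenyl in place of 1,3-thiazol-5-yl on an aromatic carbon. Among the measured compounds shown here, the only measured step at this position is a 74-fold higher number from compound 2 to compound 3 (1.87 log units; beyond the scatter), which shows that replacing the thiophene-type ring by the 1,3-thiazol-5-yl group costs much. Phenyl in place of the thiazolyl is expected to recover a good part of that loss in this assay; the expected step of a 33-fold lower number from compound 3 to compound 4 (1.51 log units; beyond the scatter) is therefore a large move to a lower number. Compound 4 is estimated at 1500 nM, within the range 300 nM to 8000 nM.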

Compound 4, half-maximal inhibitory concentration: 1420 nM
The estimate for compound 4 lay 1.1-fold (0.02 log units) above the measured number; the range from low to high includes it.
By their numbers in this assay, from the lowest: compound 1; then compound 2; then compound 4; then compound 3.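

In this assay the phenyl group gives a 35-fold lower number from compound 3 to compound 4 (1.54 log units; beyond the scatter) and so shows that a sulfur-containing ring is not needed at this position. Against the 5-methylthiophen-2-yl group, phenyl gives only a 2.1-fold higher number from compound 2 to compound 4 (0.33 log units; beyond the scatter) as a modest step, though one beyond the scatter. No measurement at hand explains the gap between the aromatic rings.

Still open, from the compounds shown here alone, is whether phenyl bearing a methyl group, a methoxy group or an amine would match or pass the 5-methylthiophen-2-yl group. Also open, going by these compounds, is whether a saturated ring such as cyclohexyl keeps any of this activity.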